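Acetamido on compound 3: expected step

The compounds below may be only part of what the source reports. "The series", "measured", "known", "first", "only" and "open" are said of these compounds alone.

In a functional assay on MCF7 cells (Homo sapiens) for antiproliferative activity, read by sulforhodamine B assay, with a stated time of 72 h (on this read-out lower numbers stand for stronger inhibition and higher numbers for weaker inhibition), compound 1 (`CC(C)C[C@H](NC(=O)CSc1cc(NS(=O)(=O)c2ccc(Cl)cc2)c2ccccc2c1O)B(O)O`) gives 10400 nM, compound 2 (`CC(=O)Nc1ccc(S(=O)(=O)Nc2cc(SCC(=O)N[C@@H](CC(C)C)B(O)O)c(O)c3ccccc23)cc1`) gives 8660 nM and compound 3 (`CC(C)C[C@H](NC(=O)CCSc1cc(NS(=O)(=O)c2ccccc2)c2ccccc2c1O)B(O)O`) gives 7460 nM. Compound 3 therefore lies within the scatter of both other compounds, and the three values set no order among them.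

Compound 4 (`CC(=O)Nc1ccc(S(=O)(=O)Nc2cc(SCCC(=O)N[C@@H](CC(C)C)B(O)O)c(O)c3ccccc23)cc1`) carries acetamido in place of hydrogen on an aromatic carbon, para to a large group, taking phenyl to 4-acetamidophenyl: acetamido in place of hydrogen on an aromatic carbon.

Among the measured compounds shown here, the one measured step that bears on this change also installs acetamido on an aromatic carbon, though in place of chloro: a 1.2-fold lower number from compound 1 to compound 2 (0.08 log units; within the scatter), within the scatter. No replacement of hydrogen by acetamido has been measured, so this is only an indirect guide. On that evidence, no step beyond the scatter is expected in this assay. The estimated step is a 1.1-fold lower number from compound 3 to compound 4 (0.06 log units; within the scatter). For compound 4, the estimated value is 6500 nM, with an expected range of 3200 nM to 13000 nM.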

Compound 4, half-maximal inhibitory concentration: 6620 nM
The estimate for compound 4 lay 1.0-fold (0.01 log units) below the measured number; measured number inside the range.
By their numbers in this assay, from the lowest: compounds 4, 3, 2 and 1 (each within the scatter of the next).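

In this assay the direct replacement of hydrogen by acetamido, on an aromatic carbon para to a large group, gives a 1.1-fold lower number from compound 3 to compound 4 (0.05 log units; within the scatter) and thus confirms on phenyl to 4-acetamidophenyl what the chloro replacement showed only indirectly. With acetamido held constant, a change of the group on the saturated chain carbon bound to a sulfur gives a 1.3-fold lower number from compound 2 to compound 4 (0.12 log units; within the scatter) and so adds a second change that stays unresolved from the scatter. No supporting measurement accompanies these numbers.

Going by these compounds, whether an amine or a carboxylic acid on this aromatic carbon, or a longer chain on the sulfur, would give a step beyond the scatter remains open. On these data alone, whether either change behaves alike in another cell line is also open.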